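A few compounds are considered here, and "the series" means these few. Any claim that something is new, unique, unknown or untested is made for them only; others in the source may bear on it.

Compound 1 (`Cc1nc2cnccc2n1CC1CCN(C(=O)CC(C)c2ccccc2)CC1`) gives 0.033 mg/kg in a functional assay on the whole organism (arterial blood) with Rattus norvegicus as the target; on this read-out higher numbers stand for an effect only at larger amounts of compound and lower numbers for an effect already at smaller amounts
Compound 2 (`COc1ccccc1CCC(=O)N1CCC(Cn2c(C)nc3cnccc32)CC1`) gives 0.045 mg/kg in this assay

Compound 2, at 0.045 mg/kg in this assay, lies within the scatter of compound 1, so the two cannot be ranked. Compound 3 (`Cc1nc2cnccc2n1CC1CCN(C(=O)CN(C)c2ccccc2)CC1`) carries methyl(phenyl)amino in place of 2-methoxybenzyl on a saturated chain carbon bound to a carbonyl carbon. Among the measured compounds shown here, only one measured step bears on this place (a 1.4-fold higher number from compound 1 to compound 2 (0.13 log units; within the scatter)), and it stayed within the scatter when 2-methoxybenzyl replaced 1-phenylethyl. For the measured compounds named here, no measured compound carries methyl(phenyl)amino, so this single step is a thin guide. A step beyond the scatter is not expected in this assay in either direction, though the range is kept wide. The expected change is small (a 1.1-fold higher number from compound 2 to compound 3 (0.05 log units; within the scatter)). In this assay compound 3 is estimated at 0.05 mg/kg (range 0.015 mg/kg to 0.2 mg/kg).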

Compound 3, dose for 50% inhibition: 0.31 mg/kg
The estimate for compound 3 lay 6.2-fold (0.79 log units) below the measured number, outside the stated range (above it).
By their numbers in this assay, from the lowest: compounds 1 and 2 (each within the scatter of the next); then compound 3.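

Up to compound 2, this place looked tolerant, since the swap of 1-phenylethyl for 2-methoxybenzyl stayed within the scatter. Compound 3 shows that it is not indifferent to every group: in this assay, methyl(phenyl)amino in place of 2-methoxybenzyl gives a 6.9-fold higher number from compound 2 to compound 3 (0.84 log units; beyond the scatter), so a larger dose is needed for the same effect. The comparison with 1-phenylethyl points the same way, with a 9.4-fold higher number from compound 1 to compound 3 (0.97 log units; beyond the scatter), and no available evidence accounts for this shift.

The three compounds leave open whether the higher number goes with the nitrogen in the entering group or with the methyl on that nitrogen. A phenylamino group without the methyl, or a phenoxy group with oxygen in place of that nitrogen, would help to separate these two readings.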